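Chromene isoxazole series: ester and aryl changes

The source may hold more compounds than are shown below. What is called first, only, known or untested is meant among the compounds shown, and "the series" means these compounds.

- compound 1 `CCOC(=O)C1=Cc2ccccc2OC1(OCc1cc(-c2ccc(OC)cc2)no1)C(F)(F)F`: in a functional assay on HeLa cells (Homo sapiens) for inhibition, read by MTT assay, with a stated time of 24 h (a higher number here means a weaker inhibitor, a lower number a stronger inhibitor), compound 1 gives > 150000 nM, which is a limit of the assay and not a number.
- compound 2 `CCOC(=O)C1=Cc2ccccc2OC1(OCc1cc(-c2cccc(C(F)(F)F)c2)no1)C(F)(F)F`: in this assay compound 2 gives 21400 nM.
- compound 3 `O=C(O)C1=Cc2ccccc2OC1(OCc1cc(-c2cccc(C(F)(F)F)c2)no1)C(F)(F)F`: in this assay compound 3 gives > 150000 nM, again a limit rather than a number.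

For the measured compounds named here, compound 2 is the one member with a measured number. From compound 2 the change 4-methoxyphenyl in place of 3-(trifluoromethyl)phenyl on an aromatic carbon leads to an at least 7.0-fold higher number from compound 2 to compound 1 (0.84 log units; beyond the scatter). The change hydrogen in place of ethyl on an oxygen next to a carbonyl group leads to an at least 7.0-fold higher number from compound 2 to compound 3 (0.84 log units; beyond the scatter). Both moves end at the limit of > 150000 nM in this assay, at which 2 of the 3 values shown sit.

Compound 4 `COc1ccc(-c2cc(COC3(C(F)(F)F)Oc4ccccc4C=C3C(=O)O)on2)cc1` is not yet measured. It differs from compound 3 by 4-methoxyphenyl in place of 3-(trifluoromethyl)phenyl on an aromatic carbon, the same change that separates compound 2 from compound 1, at a place described in identical words. The two cores differ by hydrogen in place of ethyl on an oxygen next to a carbonyl group.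

The expectation rests on compound 3 already sitting at the limit of > 150000 nM in this assay, at which 2 of the 3 values shown sit, and on an at least 7.0-fold higher number from compound 2 to compound 1 (0.84 log units; beyond the scatter). Compound 4 is expected to give 400000 nM, between 150000 nM and 1500000 nM, most probably reported only as a limit. The step that the limit leaves unreadable from compound 3 to compound 4 is the expected one, without a measured lower bound to anchor it.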

Compound 4, half-maximal inhibitory concentration: > 150000 nM
Compound 4 gave a limit, no number; the forecaster's own chance of this, stated with the estimate: 95%; the middle value lies beyond the limit too.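

In this assay compound 4 gives > 150000 nM, a limit and not a number. No new step can be read from compound 4 to compound 3 or compound 1, because all three sit at a limit: the limit of > 150000 nM in this assay, at which 3 of the 4 values shown sit.

The compounds shown leave open how far compound 1, compound 3 and compound 4 differ from one another.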